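The source may report more compounds than this note shows. Statements on the series, on what has been measured and on what is new or still open speak of the compounds shown alone.

Compound 2, `COc1ccc(C(=O)c2sc(Nc3ccccc3)c(C(=O)O)c2C)cc1`, gives 41.2% in a functional assay, with a stated time of 150 min, tested at 20 ug/mL (a higher number here means a stronger effect of the compound at the concentration tested, a lower number a weaker effect), the highest of the three numbers in hand. Compound 1, `COC(=O)c1c(Nc2ccccc2)sc(C(=O)c2ccc(C)cc2)c1C`, gives 6.06% in this assay, and compound 3, `COc1ccc(C(=O)c2sc(Nc3ccc(F)cc3)c(C(=O)O)c2C)cc1`, gives 3.58%. Among the compounds with values here, the only single-point step among the measured compounds is a number 37.6 percentage points lower from compound 2 to compound 3 (beyond the scatter), which concerns a change on the ring attached to the amine nitrogen, not the ring carrying the carbonyl.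

Compound 4, `Cc1ccc(C(=O)c2sc(Nc3ccccc3)c(C(=O)O)c2C)cc1`, differs from compound 2 by methyl in place of methoxy on an aromatic carbon. Within the data shown here, no measured step addresses this exact change. Compound 1 carries the same 4-methylphenyl group as compound 4 but also differs from compound 2 in the acid being an ester, so the pair of compound 1 and compound 2 shows two changes at once, and their values cannot be separated into a contribution from either one. The step from compound 2 to compound 3 shows that a small change on one of the aromatic rings can move the number well beyond the scatter, so a large effect on this assay cannot be ruled out.

On balance, compound 4 is expected to sit below compound 2, with a number 19.2 percentage points lower from compound 2 to compound 4 (beyond the scatter) as the estimated step. The expected value for compound 4 is 22%, in a range from 4% to 45%.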

Compound 4, a percentage reported as activity, at one concentration (the size of the read-out at that concentration, not a potency): 2.68%
Estimate against measurement, compound 4: 19.3 percentage points above; the whole stated range lies above it.
By their numbers in this assay, from the lowest: compounds 4, 3 and 1 (each within the scatter of the next); then compound 2.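

In this assay, within the data shown here, exchanging 4-methoxyphenyl for 4-methylphenyl gives a number 38.5 percentage points lower from compound 2 to compound 4 (beyond the scatter), the first direct reading of this position para to a large group, and it shows that this single change, with the carboxylic acid kept, is enough for a large loss. The step of a number 3.4 percentage points lower from compound 1 to compound 4 (within the scatter) adds that, with 4-methylphenyl in place, exchanging the methyl ester for the carboxylic acid leaves the read-out within the scatter, so the low number of compound 1 can be accounted for without the ester playing any resolved part. No measurement given here explains why the methoxy group and the methyl group differ so sharply at this position.

Going by these compounds, the ester-to-acid change has been read only with 4-methylphenyl, so what it does alongside 4-methoxyphenyl remains open, and a low read-out at a single concentration leaves little room to see any further loss. On these data alone, it is also open whether the methoxy group itself is required or whether an ethoxy group, a hydroxyl group or a chlorine atom on the same aromatic carbon would restore the number seen for compound 2.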